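The source may hold more compounds than are shown below. What is called first, only, known or untested is meant among the compounds shown, and "the series" means these compounds.

Measured compounds:
compound 1, `CCOC(=O)c1sc(-c2cccc(NC(=O)c3ccc(F)cc3)c2)nc1Nc1ccc(N2CCN(C)CC2)cc1`, 3.53%
compound 2, `CCOC(=O)c1sc(-c2cccc(NC(=O)c3ccc(C(F)(F)F)cn3)c2)nc1Nc1ccc(N2CCN(C)CC2)cc1`, 19%
compound 3, `CCOC(=O)c1sc(-c2cccc(NC(=O)[C@H]3CC[C@H](C)CC3)c2)nc1Nc1ccc(N2CCN(C)CC2)cc1`, 19.9%

In a functional assay on Ramos cells (Homo sapiens) for antiproliferative activity, read by CCK-8 assay, with a stated time of 72 h, tested at 40 uM (a lower number here means less inhibition, a higher number more inhibition at the concentration tested (going by the name of the read-out)), compound 1 gives the lowest of the three numbers. Its nearest neighbour is compound 2, a number 15.5 percentage points higher from compound 1 to compound 2 (beyond the scatter), and its furthest is compound 3, a number 16.4 percentage points higher from compound 1 to compound 3 (beyond the scatter); the two higher compounds sit close to each other, a number 0.9 percentage points higher from compound 2 to compound 3 (within the scatter).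

Compound 4, `CN1CCN(c2ccc(Nc3nc(-c4cccc(NC(=O)c5ccc(F)cc5)c4)sc3C(N)=O)cc2)CC1`, is not yet measured. It differs from compound 1 in one place: amino in place of ethoxy on a carbonyl carbon. Cut one bond further out, the difference reads ethoxycarbonyl to carbamoyl.

None of the three measured steps bears on this change. All of them alter the group on the carbonyl carbon of the amide, while the ethoxycarbonyl in compound 1 is kept in compounds 2 and 3 alike. The data therefore give no size or direction for a step from ethoxycarbonyl to carbamoyl, and the expectation in this assay rests on compound 1 alone, which gives 3.53%, near the bottom of the range this read-out can take.

With nothing to push the number either way, compound 4 is expected to stay close to compound 1, a number 4.5 percentage points higher from compound 1 to compound 4 (within the scatter), a step not expected to exceed the scatter. The estimate for compound 4 in this assay is 8%, with a range from 0% to 25%.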

Compound 4, a percentage reported as inhibition, at one concentration (the size of the read-out at that concentration, not a potency): 95.9%
Estimate against measurement, compound 4: 87.9 percentage points below; the whole stated range lies below it.
By their numbers in this assay, from the lowest: compound 1; then compounds 2 and 3 (each within the scatter of the next); then compound 4.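

In this assay, the group on the carbonyl carbon whose other neighbour is an aromatic carbon proves decisive: amino in place of ethoxy gives a number 92.4 percentage points higher from compound 1 to compound 4 (beyond the scatter), a large step, whereas changing the amide group gave only a number 16.4 percentage points higher from compound 1 to compound 3 (beyond the scatter). The earlier compounds shown here all kept ethoxycarbonyl, so only this result shows that the read-out can reach the high end of its range, with carbamoyl bringing a hydrogen-bond donor that ethoxy lacks. No measurement shown accounts for the size of this step.

Carbamoyl appears here only with the 4-fluorophenyl amide, so it remains open whether the step carries over to the 5-(trifluoromethyl)pyridin-2-yl or 4-methylcyclohexyl amides. Also open, going by these compounds, is how a methylamino, a dimethylamino or a carboxylic acid at this place would compare.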